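Swapping the aryl group on the sulfonyl sulfur

The source may hold more compounds than are shown below. What is called first, only, known or untested is meant among the compounds shown, and "the series" means these compounds.

Within the data shown here, compound 2 `COc1ccc(S(=O)(=O)N(C)CCOCC(=O)N(C)Cc2ccc(C3=NCCN3)cc2)c(C)c1` gives 5.5 nM in an assay on HEK293 cells for displacement of a labelled ligand from B1 bradykinin receptor (Homo sapiens), read by scintillation counting (a lower number here means a stronger inhibitor, a higher number a weaker inhibitor), the second highest of the three numbers known so far. Compound 1 `COc1cc(C)c(S(=O)(=O)N(C)CCOCC(=O)N2CCN(C3CCN(C4CC4)CC3)CC2)c(C)c1` gives 0.8 nM, while compound 3 `COc1cc(C)c(S(=O)(=O)N(C)CCOCC(=O)N2CCN(CCN(C)C)CC2)c(C)c1` gives 106 nM. Among the measured compounds shown here, the only measured step, a 130-fold higher number from compound 1 to compound 3 (2.12 log units; beyond the scatter), changes a group on an amine nitrogen in a ring, not on the sulfonyl sulfur, so it says nothing direct about the change considered here. Compound 4 `Cc1c(Cl)cccc1S(=O)(=O)N(C)CCOCC(=O)N(C)Cc1ccc(C2=NCCN2)cc1` differs from compound 2 in one place: 3-chloro-2-methylphenyl in place of 4-methoxy-2-methylphenyl on a sulfonyl sulfur. For the measured compounds named here, with no measured step on this part of the shared core, the direction of the change cannot be read from the data, and only a modest step in a 1.8-fold higher number from compound 2 to compound 4 (0.26 log units; within the scatter) is expected, so compound 4 is estimated at 10 nM, between 2 nM and 50 nM.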

Compound 4, inhibition constant: 6.8 nM
Compound 4: the middle estimate sits 1.5-fold (0.17 log units) above what was measured, within the range that was stated.
By their numbers in this assay, from the lowest: compound 1; then compounds 2 and 4 (each within the scatter of the next); then compound 3.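

In this assay, among these compounds, the step of a 1.2-fold higher number from compound 2 to compound 4 (0.09 log units; within the scatter) lies within the scatter, the first reading on the sulfonyl sulfur. On this core, then, 3-chloro-2-methylphenyl and 4-methoxy-2-methylphenyl cannot be told apart, even though the leaving group carries a hydrogen-bond acceptor and the entering group carries none. No evidence is at hand to explain this match.

As far as these compounds go, whether an aryl group bearing an amine or a carboxylic acid, or a plain alkyl chain, would fit this place equally well stays open. So does whether the same swap holds on the core of compound 1.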